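A few compounds are considered here, and "the series" means these few. Any claim that something is new, unique, unknown or untested is made for them only; others in the source may bear on it.

Working notes on the series. Compound 1 `O=C(CCc1ccccc1)c1nc2ncccc2o1` carries a phenyl at the end of its ketone chain; in an assay on HEK-293T cells for inhibition of diacylglycerol lipase-alpha (Homo sapiens), read by colorimetric assay (on this read-out higher numbers stand for weaker inhibition and lower numbers for stronger inhibition), compound 1 gives 18200 nM. Compound 2 `CC(=O)c1nc2ncccc2o1` is the short methyl ketone. In this assay compound 2 reaches only a limit, > 10000 nM. Compound 3 `CCCCCC(=O)c1nc2ncccc2o1` is the pentyl ketone. In this assay compound 3 likewise reaches only a limit, > 10000 nM. Among the measured values compound 3 therefore stands at the limit, with compound 2 sitting at the same limit and compound 1 the single numbered result (the limit of > 10000 nM in this assay, at which 2 of the 3 values shown sit). Both measured steps that touch compound 3 are unreadable: a step that the limit leaves unreadable from compound 1 to compound 3 and a step that the two limits leave unreadable from compound 2 to compound 3 are each masked by the limit, so neither yields a direction or a size.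

Compound 4 `CCCCCCCCCCCCCC(=O)c1nc2ncccc2o1` lengthens the chain further: octyl in place of hydrogen on a saturated chain carbon, five bonds along the chain from a carbonyl carbon. No readable step bears on this change, since the one chain extension already measured, from compound 2 to compound 3, runs between two limits. For the measured compounds named here, with compound 3 at the limit and no measured step pointing either way, no movement beyond the scatter can be expected in this assay. Compound 4 is estimated at 20000 nM, with a range of 8000 nM to 60000 nM. The expected step from compound 3 is therefore a step that the limit leaves unreadable from compound 3 to compound 4.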

Compound 4, half-maximal inhibitory concentration: 74.1 nM
Compound 4: the middle estimate sits 270-fold (2.43 log units) above what was measured, and the stated range ends above it.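

In this assay, for the compounds shown here, octyl in place of hydrogen on a saturated chain carbon, five bonds along the chain from a carbonyl carbon, gives an at least 130-fold lower number from compound 3 to compound 4 (2.13 log units; beyond the scatter), the first readable step and a large one. The other steps cannot be read and gave no direction for the ketone chain, whereas this one shows that the read-out responds strongly to a change at this position, with the long chain of compound 4 clearing the limit that holds compound 2 and compound 3. The size of the step stands only as a lower bound because compound 3 holds a limit and not a number: the limit of > 10000 nM in this assay, at which 2 of the 4 values shown sit.

Open, as far as these compounds go, is whether the read-out falls gradually as the chain grows or only near the length in compound 4, and whether a longer chain would lower it further. Also open, from the compounds shown here alone, is how this assay would respond to a carboxylic acid or an amine on the chain of compound 4.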